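Replacing the Diethylaminophenyl Group: What to Expect

The source may report more compounds than this note shows. Statements on the series, on what has been measured and on what is new or still open speak of the compounds shown alone.

Of the compounds shown here, three sharing one core have been tested in a functional assay on HOS-TE85 cells (Homo sapiens) for inhibition, read by CCK-8 assay, with a stated time of 72 h; a higher number here means a weaker inhibitor, a lower number a stronger inhibitor. Compound 1 `Cc1ccnc(N2C(=O)CS[C@@H]2c2cccc(C(=O)NCCCCn3cccn3)c2)c1` gives 21.9 nM in this assay. Compound 2 `CCN(CC)c1ccc(N2C(=O)CSC2c2cccc(C(=O)NCCCCc3ccccc3)c2)cc1` reaches only a limit of this assay, > 1000 nM, so no number is known for it. Compound 3 `COc1ccccc1N1C(=O)CSC1c1cccc(C(=O)NCCCCn2cncn2)c1` likewise reaches only a limit, > 1000 nM. Compound 2 therefore stands at the weak end of what has been seen so far, sitting at the limit of > 1000 nM in this assay, at which 2 of the 3 values shown sit, and its position cannot be fixed more finely than that.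

Compound 4 `COc1c(F)cccc1N1C(=O)CSC1c1cccc(C(=O)NCCCCc2ccccc2)c1` has not yet been measured. It differs from compound 2 in one place: 3-fluoro-2-methoxyphenyl in place of 4-(diethylamino)phenyl on an amide-type nitrogen in a ring. Going by the values given here, no pair of measured compounds traces this change, so the size of the step must be estimated rather than read off. Because compound 2 already sits at > 1000 nM, the step from it to compound 4 is expected to be small, a step that the limit leaves unreadable from compound 2 to compound 4, with no clear direction beyond the scatter. The account therefore expects compound 4 to give about 1500 nM in this assay, within a range from 400 nM to 6000 nM, and it is quite possible that this assay will again return only a limit for compound 4.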

Compound 4, half-maximal inhibitory concentration: 26.2 nM
For compound 4 the middle estimate is 57-fold (1.76 log units) above the measured one, outside the stated range (below it).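

Going by these compounds alone, the result shows that the group on the amide-type nitrogen in the ring can decide whether a compound of this kind reads as a strong inhibitor in this assay, something the earlier compounds could not show, as none of them differ in only one place. Placing 3-fluoro-2-methoxyphenyl in place of 4-(diethylamino)phenyl, with the rest of the molecule unchanged, gives an at least 38-fold lower number from compound 2 to compound 4 (1.58 log units; beyond the scatter), so the side chain of compound 2 does not by itself hold a compound at the weak end. The true size of this step remains unknown, because the value of compound 2 is a limit and not a number: the limit of > 1000 nM in this assay, at which 2 of the 4 values shown sit.

As far as these compounds go, what remains open is whether the step comes from the loss of 4-(diethylamino)phenyl or from the arrival of 3-fluoro-2-methoxyphenyl, and an unsubstituted phenyl at this place would help to separate the two. From the compounds shown here alone, it is also open whether the fluorine, the methoxy group or both together matter, and whether 3-fluoro-2-methoxyphenyl would give a similar reading on the side chain of compound 1.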